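Trimethoxyphenyl series: vinyl replaces methylpyrazolyl on the aryl

The source may hold more compounds than are shown below. What is called first, only, known or untested is meant among the compounds shown, and "the series" means these compounds.

Measured so far in a functional assay on A549 cells (Homo sapiens) for inhibition, read by CCK-8 assay, with a stated time of 48 h; on this read-out lower numbers stand for stronger inhibition and higher numbers for weaker inhibition:
- compound 1, `COc1ccc(-c2cc3nccc(-c4cc(OC)c(OC)c(OC)c4)n3n2)cc1[N+](=O)[O-]`: > 10000 nM, a limit of the assay, not a number
- compound 2, `COc1cc(-c2ccnc3cc(-c4ccc(-c5cnn(C)c5)cc4)nn23)cc(OC)c1OC`: 1150 nM

Within the data shown here, compound 2 holds the only number among the values shown; the other entry is a limit. That limit is described by the limit of > 10000 nM in this assay, at which 1 of the 2 values shown sits, and compound 1 sits at it. Among the measured compounds shown here, no step between measured compounds that differ in one place is available, so the size of any change in this assay cannot be read off from the pair.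

Compound 3, `C=Cc1ccc(-c2cc3nccc(-c4cc(OC)c(OC)c(OC)c4)n3n2)cc1`, is the next candidate. Its change from compound 2 is vinyl in place of 1-methyl-1H-pyrazol-4-yl on an aromatic carbon. The vinyl group that enters carries no ring and no hydrogen-bond acceptors, where the leaving group carried both; the data give no measured property that ties this to the read-out. With only compound 2 as an anchor, the expectation for the step in this assay is a mild weakening, of a size not clearly beyond the scatter.

Compound 3 is estimated at 2500 nM, within 800 nM to 8000 nM. The expected step is a 2.2-fold higher number from compound 2 to compound 3 (0.34 log units; beyond the scatter).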

Compound 3, half-maximal inhibitory concentration: 1030 nM
Compound 3: middle estimate off by 2.4-fold (0.39 log units), on the high side; measured number inside the range.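

In this assay, replacing 1-methyl-1H-pyrazol-4-yl with vinyl on an aromatic carbon para to a large group gives no change beyond the scatter (a 1.1-fold lower number from compound 2 to compound 3 (0.05 log units; within the scatter)). At this place, then, the five-membered aromatic ring and its 2 hydrogen-bond acceptors are not needed to hold the read-out at the level of compound 2, since vinyl, with no ring and 0 hydrogen-bond acceptors, gives a value within the scatter of it. No measured property shown here bears on why these two very different groups read alike.

As far as these compounds go, only these two groups can be compared at this place, so it remains open whether any group here moves the number beyond the scatter, for example a primary amine, a carboxylic acid or a longer alkyl chain. Among these compounds, compound 1 remains a limit of the assay, not a number (> 10000 nM), and no step to it can be read, so what separates it from the measured compounds stays undefined in this assay.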